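The source may report more compounds than this note shows. Statements on the series, on what has been measured and on what is new or still open speak of the compounds shown alone.

Of the compounds shown here, two have so far been measured in an ADME assay on microsomes (Canis lupus familiaris) for metabolic stability; a lower number here means that the compound disappears faster, a higher number that the compound lasts longer. Compound 1 `O=C1c2cc(-c3ccc(OC(F)(F)F)cc3)ccc2OCCN1Cc1ncccn1` gives 5.9 h in this assay. Compound 2 `O=C1c2cc(-c3ccc(OC(F)(F)F)cc3)ccc2CCN1Cc1ncccn1` shares most of its structure with compound 1. In this assay compound 2 gives 2.62 h, the lower of the two numbers, and the gap to compound 1 is wider than the usual scatter of repeated measurements. Compound 3 `O=C1c2cc(-c3ccc(C(F)(F)F)cc3)ccc2CCN1Cc1ncccn1` has not yet been measured. It differs from compound 2 in one place: trifluoromethyl in place of trifluoromethoxy on an aromatic carbon. Within the data shown here, neither measured compound carries this particular change, so no measured step is available to lean on, and the expectation rests on the change itself and on the value of compound 2. Across this change the expected step is small, a 1.1-fold higher number from compound 2 to compound 3 (0.06 log units; within the scatter), within the scatter in either direction. Compound 3 is therefore expected to give about 3 h in this assay, with a likely range from 1.5 h to 6 h.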

Compound 3, half-life: 5.33 h
The estimate for compound 3 lay 1.8-fold (0.25 log units) below the measured number, and the stated range covers the measured number.
By their numbers in this assay, from the lowest: compound 2; then compounds 3 and 1 (each within the scatter of the next).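

Among these compounds, replacing trifluoromethoxy with trifluoromethyl on an aromatic carbon, para to a large group, gives a 2.0-fold higher number from compound 2 to compound 3 (0.31 log units; beyond the scatter) in this assay and provides the first measured reading of this change. The step is modest, but it lies beyond the usual scatter, so for this one pair the group at this position does affect the half-life. Nothing available here accounts for the difference.

Among the compounds shown here, the change is seen in only one pair, so it remains open whether the same swap on the core of compound 1 would give a similar step. On these data alone, how a nitrile, an amine or a carboxylic acid at this position would compare in this assay also remains open.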